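The source may hold more compounds than are shown below. What is called first, only, known or untested is meant among the compounds shown, and "the series" means these compounds.

Measured compounds:

Compound 1, `CCOC(=O)c1ccc(NC(=O)N2CC2C#N)cc1` — 3000 nM
Compound 2, `N#CC1CN1C(=O)NCc1ccccc1` — 9000 nM
Compound 3, `CCCCNC(=O)N1CC1C#N` — 17000 nM

All three were tested in a functional assay on RPMI-8226 cells (Homo sapiens) for inhibition; on this read-out lower numbers stand for stronger inhibition and higher numbers for weaker inhibition. Compound 1, with its ester-bearing aryl urea, gives 3000 nM, while compound 2 gives 9000 nM and compound 3 gives 17000 nM. Compound 3 thus carries the highest of the three numbers. Its gap to compound 2 lies within the scatter of repeated measurements, so the two cannot be ranked against each other; its gap to compound 1, however, lies beyond the scatter, so compound 3 is clearly the weaker of that pair in this assay.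

The next compound to be examined is compound 4, `CC(C)(C)NC(=O)N1CC1C#N`. It differs from compound 3 in one place only: tert-butyl in place of butyl on an amide-type nitrogen. The two share every atom and differ only in how the four-carbon chain is joined. Among the compounds with values here, no measured pair in this set shows the effect of such a rearrangement on the amide-type nitrogen, so there is nothing to anchor the direction of the step. Compound 4 is therefore expected to sit close to compound 3, with a step of a 1.2-fold higher number from compound 3 to compound 4 (0.07 log units; within the scatter) that is not expected to exceed the scatter. The estimate for compound 4 in this assay is 20000 nM, within a range from 6000 nM to 60000 nM.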

Compound 4, half-maximal inhibitory concentration: 120000 nM
Compound 4: the middle estimate sits 6.0-fold (0.78 log units) below what was measured, and the stated range ends below it.
By their numbers in this assay, from the lowest: compound 1; then compounds 2 and 3 (each within the scatter of the next); then compound 4.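

In this assay, tert-butyl in place of butyl on the amide-type nitrogen gives a 7.1-fold higher number from compound 3 to compound 4 (0.85 log units; beyond the scatter), so this position responds to how the four-carbon chain is joined and not only to which atoms it contains. This is the only step shown between compounds that differ in one place, and the two groups match in heavy atoms, rings, hydrogen-bond donors and acceptors, and net charge, so none of these counts separates them. No measurement at hand bears on what lies behind the step.

The compounds shown leave open whether the higher number belongs to tert-butyl alone or would also come with other branched chains such as isopropyl or sec-butyl, and what a longer straight chain such as hexyl or a ring such as cyclohexyl would give on the same nitrogen. They also leave open whether an amine or a carboxylic acid at the end of the butyl chain would move the number in either direction.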